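The compounds below may be only part of what the source reports. "The series", "measured", "known", "first", "only" and "open" are said of these compounds alone.

Three compounds share one core and differ only in the aryl group on a double-bonded ring carbon. In a functional assay on DU-145 cells (Homo sapiens) for cytotoxicity (on this read-out higher numbers stand for weaker inhibition of growth and lower numbers for stronger inhibition of growth), compound 1 `COc1ccc(C2=C(c3ccc(SC)cc3)CC3CCCN3C2=O)cc1Br`, which carries 3-bromo-4-methoxyphenyl, gives 900 nM. Compound 2 `COc1ccc(C2=C(c3ccc(SC)cc3)CC3CCCN3C2=O)cc1OC` gives 1500 nM. The step between these two is a 1.7-fold higher number from compound 1 to compound 2 (0.22 log units; within the scatter), so swapping bromo for methoxy shows no real effect. Compound 3 `CSc1ccc(C2=C(c3ccc(O)c(O)c3)C(=O)N3CCCC3C2)cc1`, which carries 3,4-dihydroxyphenyl, gives 60000 nM, the highest number of the three and so the weakest inhibition of growth.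

Compound 4 `COc1ccc(C2=C(c3ccc(SC)cc3)CC3CCCN3C2=O)cc1` keeps the core but changes that group: 4-methoxyphenyl in place of 3,4-dihydroxyphenyl on a double-bonded ring carbon. Put simply, 4-methoxyphenyl stands in place of 3,4-dihydroxyphenyl. The most relevant evidence is a 67-fold higher number from compound 1 to compound 3 (1.82 log units; beyond the scatter), a large step that comes with the move to 3,4-dihydroxyphenyl. Going by the values given here, compound 4 undoes that move, but it has neither the bromo of compound 1 nor the second methoxy of compound 2, and no measured compound shows the effect of leaving both out. A large step down in this assay is therefore expected, back towards the level of compound 1 and compound 2. The expected size is a 40-fold lower number from compound 3 to compound 4 (1.60 log units; beyond the scatter). The estimate for compound 4 is 1500 nM, with a range from 300 nM to 7000 nM.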

Compound 4, concentration for 50% growth inhibition: 900 nM
The estimate for compound 4 lay 1.7-fold (0.22 log units) above the measured number; the range from low to high includes it.
By their numbers in this assay, from the lowest: compounds 1, 4 and 2 (each within the scatter of the next); then compound 3.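

Compound 4 shows that the 4-methoxyphenyl group alone is enough to stay level with the more heavily substituted rings in this assay: hydrogen in place of methoxy gives a 1.7-fold lower number from compound 2 to compound 4 (0.22 log units; within the scatter) and hydrogen in place of bromo gives no change at the digits printed from compound 1 to compound 4 (within the scatter), so neither extra group shows any real effect at this position. The step of a 67-fold lower number from compound 3 to compound 4 (1.82 log units; beyond the scatter) therefore ties the large gap to the 3,4-dihydroxyphenyl group itself, since leaving out the bromo of compound 1 or the second methoxy of compound 2 does not produce it. Nothing measured here explains why this one ring stands so far from the other three.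

From the compounds shown here alone, it remains open which part of the 3,4-dihydroxyphenyl group carries the large step, since its two hydroxy groups appear only together, and a single hydroxy on the ring could read either way. Going by these compounds, it also remains open how far this position tolerates other groups, such as an amine, a carboxylic acid or a longer chain like ethoxy in place of the methoxy of compound 4.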